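The source may hold more compounds than are shown below. What is called first, only, known or untested is meant among the compounds shown, and "the series" means these compounds.

Measured so far in a functional assay on HEK293 cells for positive allosteric modulation of metabotropic glutamate receptor 5 (Homo sapiens), read by FLIPR and calcium flux; on this read-out lower numbers stand for an effect already at smaller amounts and higher numbers for an effect only at larger amounts of compound:
- compound 1 `CC(C)NC(=O)c1ccc(C#Cc2ccccc2)nc1` — 62 nM
- compound 2 `Cc1cccc(C#Cc2ccc3c(n2)CCN(C2CCCC2)C3=O)c1` — 7.5 nM
- compound 3 `Cc1cccc(C#Cc2ccc3c(n2)CCN(C2CCCCC2)C3=O)c1` — 36 nM

Compound 3 has the second highest of the three numbers in this assay. Its nearest neighbour is compound 1, whose number lies within the scatter of that of compound 3. Among the measured compounds shown here, its furthest is compound 2, from which it is separated by the only single-point step measured, a 4.8-fold higher number from compound 2 to compound 3 (0.68 log units; beyond the scatter), a change of the ring on the amide-type nitrogen.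

Compound 4 `O=C1c2ccc(C#Cc3cccs3)nc2CCN1C1CCCCC1` is the next member to be measured. It differs from compound 3 by thiophen-2-yl in place of 3-methylphenyl on a triple-bonded carbon. For the measured compounds named here, no measured step bears on this change: the one step on record concerns the ring on the amide-type nitrogen and not the aryl group on the triple-bonded carbon, and compound 1 differs from compounds 2 and 3 in more than one place. With nothing to steer the expectation in either direction, the step is expected to stay within the scatter. For compound 4 the expected value in this assay is 55 nM, with a range from 18 nM to 170 nM. That estimate corresponds to an expected step of a 1.5-fold higher number from compound 3 to compound 4 (0.18 log units; within the scatter).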

Compound 4, half-maximal effective concentration: 13 nM
Compound 4: middle estimate off by 4.2-fold (0.63 log units), on the high side; the measured number lies below the stated range.
By their numbers in this assay, from the lowest: compounds 2 and 4 (each within the scatter of the next); then compounds 3 and 1 (each within the scatter of the next).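

In this assay, the group on the triple-bonded carbon turns out to affect the number on the shared core: with cyclohexyl held fixed on the amide-type nitrogen, thiophen-2-yl in place of 3-methylphenyl gives a 2.8-fold lower number from compound 3 to compound 4 (0.44 log units; beyond the scatter), beyond the scatter. Among the compounds shown here, until now the only single-place step concerned the ring on the amide-type nitrogen, so this is the first reading at this position. The smaller five-membered ring with sulfur replaces the six-membered carbon ring, but nothing on hand explains the lower number.

A thiophen-3-yl or furan-2-yl group at this place would show whether the step depends on the sulfur, on its placing in the ring, or on the five-membered ring as such. Also open, going by these compounds, is whether the step holds with cyclopentyl on the amide-type nitrogen, the group involved in a 4.8-fold higher number from compound 2 to compound 3 (0.68 log units; beyond the scatter).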